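A meta substituent swap on the arylpiperazine tail

The source may report more compounds than this note shows. Statements on the series, on what has been measured and on what is new or still open speak of the compounds shown alone.

Measured so far:
compound 1, `CCC(C(=O)N1CCN(c2ccccc2Cl)CC1)N1C(=O)CCC1=O` — 25%
compound 2, `CCC(C(=O)N1CCN(c2cccc(OC)c2)CC1)N1C(=O)CCC1=O` — 0%

Both compounds were tested in a functional assay on the whole organism (strain Swiss) with Mus musculus as the target, in the maximal electroshock model, with a stated time of 0.5 h, at a dose of 300 mg/kg by the intraperitoneal route; a lower number here means a weaker effect, a higher number a stronger effect of the compound at the dose given. Among the measured compounds shown here, compound 1 gave 25%, while compound 2 gave 0%, the lower of the two numbers; the single measured step, a number 25 percentage points lower from compound 1 to compound 2 (beyond the scatter), came with the replacement of 2-chlorophenyl by 3-methoxyphenyl on the amine nitrogen in the ring.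

Compound 3, `CCC(C(=O)N1CCN(c2cccc(F)c2)CC1)N1C(=O)CCC1=O`, has not yet been tested. It differs from compound 2 as follows: fluoro in place of methoxy on an aromatic carbon. For the measured compounds named here, no measured step concerns this change: the only step on record swaps the whole aryl group, not a single group on the six-membered aromatic ring of carbon only. What can be said is that compound 2 sits at the bottom of the two numbers, and that a halogen on the ring, as in compound 1, went together with 25%. A modest rise is therefore expected, a number 12 percentage points higher from compound 2 to compound 3 (beyond the scatter), but with wide uncertainty. Compound 3 is estimated at 12%, between 0% and 35%.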

Compound 3, a percentage reported as activity, at one dose (the size of the read-out at that dose, not a potency): 100%
Compound 3: middle estimate off by 88 percentage points, on the low side; the whole stated range lies below it.
By their numbers in this assay, from the lowest: compound 2; then compound 1; then compound 3.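

In this assay, the exchange of a single group on an aromatic carbon, meta to a large group, came with a number 100 percentage points higher from compound 2 to compound 3 (beyond the scatter), so the read-out depends strongly on which group sits at this place, something the earlier swap of the whole aryl group could not separate from a change of place. The exchange of 2-chlorophenyl for 3-fluorophenyl came with a number 75 percentage points higher from compound 1 to compound 3 (beyond the scatter), which shows that among these three compounds a halogen on the ring does not by itself set the read-out, and compound 3 stands highest, with its steps to both others beyond the scatter. Nothing at hand bears on the reason for either step.

The compounds shown leave open whether the high read-out belongs to fluoro in particular or would also appear with chloro, a nitrile or an amine at this place, and whether fluoro would keep it elsewhere on the ring. Going by these compounds, the read-out is also the size of the effect at one dose and no potency, so how compound 3 would fare at smaller doses stays open.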